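From compound 2 to compound 4: a larger substituent

A few compounds are considered here, and "the series" means these few. Any claim that something is new, unique, unknown or untested is made for them only; others in the source may bear on it.

Measured in an ADME assay on microsomes from liver (Homo sapiens) for metabolic stability, read by LC-MS, using NADPH, with stated times of 5 min and 30 min, tested at 1 uM; a higher number here means faster removal of the compound, a lower number slower removal:
- compound 1 `CN(c1ncco1)c1cnc(NCc2c(F)ccc3c2CCO3)n2cnnc12`: 11 mL.min-1.g-1
- compound 2 `Cc1nccn1-c1cnc(NCc2c(F)ccc3c2CCO3)c2cn[nH]c(=O)c12`: 8 mL.min-1.g-1
- compound 3 `CN(C)Cc1ccc2c(c1)CN(c1cnc(NCc3c(F)ccc4c3CCO4)n3cnnc13)C2=O`: 19 mL.min-1.g-1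

Compound 2 lies within the scatter of compound 1 and clearly lower than compound 3. Compound 4 `CN(C)C(=O)c1cc(-c2cnc(NCc3c(F)ccc4c3CCO4)c3cn[nH]c(=O)c23)n(C)n1` keeps the core of compound 2 but carries 3-(dimethylcarbamoyl)-1-methyl-1H-pyrazol-5-yl in place of 2-methyl-1H-imidazol-1-yl on an aromatic carbon. Within the data shown here, no measured pair shows this change directly. The measured values run only from compound 2 at 8 mL.min-1.g-1 to compound 3 at 19 mL.min-1.g-1, so only a modest rise is expected. The expected change, a 1.5-fold higher number from compound 2 to compound 4 (0.18 log units; within the scatter), is not expected to exceed the scatter. For compound 4 the estimated value is 12 mL.min-1.g-1, with an expected range of 6 mL.min-1.g-1 to 25 mL.min-1.g-1.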

Compound 4, intrinsic clearance in microsomes: 21 mL.min-1.g-1
Compound 4: the middle estimate sits 1.8-fold (0.24 log units) below what was measured; measured number inside the range.
By their numbers in this assay, from the lowest: compounds 2, 1, 3 and 4 (each within the scatter of the next, the first and the last beyond it).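

Measured in this assay the exchange of 2-methyl-1H-imidazol-1-yl for 3-(dimethylcarbamoyl)-1-methyl-1H-pyrazol-5-yl on this aromatic carbon gives a 2.6-fold higher number from compound 2 to compound 4 (0.42 log units; beyond the scatter) and so moves the number beyond the scatter. This is the first single-place step shown, and it makes clear that the number is sensitive to the group at this position on the shared core. Nothing measured here gives a reason for the rise. 

The compounds shown leave open whether the rise follows the dimethylcarbamoyl group or the ring carrying it. They also leave open how a primary amide or a carboxylic acid on that ring would compare.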